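From Hydroxyphenyl to Dibromo-Hydroxyphenyl on a Shared Core

The source may report more compounds than this note shows. Statements on the series, on what has been measured and on what is new or still open speak of the compounds shown alone.

Three compounds share one core and differ only in the aryl group on the carbon with a double bond to nitrogen. In a functional assay on HepG2 cells (Homo sapiens) for antiproliferative activity, read by MTT assay, with a stated time of 72 h (on this read-out lower numbers stand for stronger inhibition and higher numbers for weaker inhibition), compound 1 `O=C(N/N=C/c1ccc(Cl)c(Cl)c1)Nc1ccc(Oc2ccnc3[nH]ccc23)c(F)c1` gives 3700 nM, compound 2 `O=C(N/N=C/c1ccc(F)cc1Cl)Nc1ccc(Oc2ccnc3[nH]ccc23)c(F)c1` gives 1110 nM and compound 3 `O=C(N/N=C/c1ccc(O)cc1)Nc1ccc(Oc2ccnc3[nH]ccc23)c(F)c1` gives 1950 nM. Compound 3 holds the middle of these three numbers and lies within the scatter of both others.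

The next structure, compound 4 `O=C(N/N=C/c1cc(Br)c(O)c(Br)c1)Nc1ccc(Oc2ccnc3[nH]ccc23)c(F)c1`, has 3,5-dibromo-4-hydroxyphenyl in place of the 4-hydroxyphenyl of compound 3 (3,5-dibromo-4-hydroxyphenyl in place of 4-hydroxyphenyl on a carbon with a double bond to nitrogen). Going by the values given here, no measured compound carries bromine, so no step shows this change directly. The nearest evidence is the set of exchanges at the same place. One of them gives a 3.3-fold lower number from compound 1 to compound 2 (0.52 log units; beyond the scatter), a modest step beyond the scatter. The other two give a 1.9-fold lower number from compound 1 to compound 3 (0.28 log units; within the scatter) and a 1.8-fold higher number from compound 2 to compound 3 (0.24 log units; within the scatter), both within the scatter. Exchanges of this aryl group have therefore stayed small, even with two halogens on the ring in compound 1 and compound 2. The expected change is a 1.1-fold higher number from compound 3 to compound 4 (0.05 log units; within the scatter), which would be no step beyond the scatter. For compound 4 the estimated value is 2200 nM, with an expected range from 700 nM to 7000 nM.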

Compound 4, half-maximal inhibitory concentration: 6520 nM
Compound 4: the middle estimate sits 3.0-fold (0.47 log units) below what was measured; the measured number falls inside the stated range.
By their numbers in this assay, from the lowest: compounds 2, 3, 1 and 4 (each within the scatter of the next, the first and the last beyond it).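

Compound 4 keeps the hydroxyl group of compound 3 and gains two bromine atoms on the same ring, and in this assay this gives a 3.3-fold higher number from compound 3 to compound 4 (0.52 log units; beyond the scatter), so keeping the hydroxyl group is not enough to hold the number of compound 3. This position can also produce larger differences than the earlier compounds showed: the widest step now listed is a 5.9-fold higher number from compound 2 to compound 4 (0.77 log units; beyond the scatter), which lies beyond the scatter, whereas a 1.8-fold higher number from compound 1 to compound 4 (0.25 log units; within the scatter) stays within it, so the dibromo-hydroxyphenyl compound and the dichlorophenyl compound cannot be told apart in this test. Nothing available here offers an explanation for the rise from compound 3 to compound 4.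

The compounds shown leave open whether a single bromine on the hydroxyphenyl ring would give part of this step or whether both bromines are needed, and whether two chlorine atoms in their place would behave alike. They also leave open what a methoxy group or an amine in place of the hydroxyl group would do to the number, with or without the bromines.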